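Removing One Chlorine From the Stronger Compound

The source may report more compounds than this note shows. Statements on the series, on what has been measured and on what is new or still open speak of the compounds shown alone.

Within the data shown here, compound 2 `N=C(N)c1ccc(-c2ccc(-c3ccc(Cl)cc3)s2)cc1F` is the stronger of the two compounds measured so far: in a functional assay on ACHN cells (Homo sapiens) for inhibition, read by sulforhodamine B assay, with a stated time of 48 h (on this read-out higher numbers stand for weaker inhibition of growth and lower numbers for stronger inhibition of growth), compound 2 gives 203 nM, whereas compound 1 `N=C(N)c1ccc(-c2ccc(-c3cc(Cl)cc(Cl)c3)s2)cc1` gives 1890 nM, a gap well beyond the usual scatter. Compound 3 `N=C(N)c1ccc(-c2ccc(-c3ccccc3)s2)cc1F` has not yet been measured. It differs from compound 2 in a single place: hydrogen in place of chloro on an aromatic carbon. Among the measured compounds shown here, no pair of measured compounds shows this same change, so its effect cannot be read off directly. A modest weakening is expected, estimated as a 2.5-fold higher number from compound 2 to compound 3 (0.39 log units; beyond the scatter) in this assay. Compound 3 is therefore expected to give about 500 nM, within a range from 150 nM to 1800 nM.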

Compound 3, concentration for 50% growth inhibition: 6560 nM
For compound 3 the middle estimate is 13-fold (1.12 log units) below the measured one; the whole stated range lies below it.
By their numbers in this assay, from the lowest: compound 2; then compound 1; then compound 3.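

The chloro on this six-membered aromatic ring, para to a large group, matters greatly in this assay: the change from 4-chlorophenyl to phenyl gives a 32-fold higher number from compound 2 to compound 3 (1.51 log units; beyond the scatter), a large loss of growth inhibition. Among these compounds, this is the first direct reading of this change, and it shows that this single chlorine atom accounts for much of the strength of compound 2. Nothing measured here explains why the loss is so large.

Still open, as far as these compounds go, is whether another group in its place, such as bromo, methyl or an amine, would keep that strength.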